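The source may hold more compounds than are shown below. What is called first, only, known or untested is meant among the compounds shown, and "the series" means these compounds.

Measured in an ADME assay on microsomes from liver (Homo sapiens) for metabolic stability, with a stated time of 10 min; on this read-out higher numbers stand for a more stable compound and lower numbers for a less stable compound:
Compound 1 `CC(=O)N1CC[C@@H](C(=O)N2CC[C@](c3ccc(C(OCc4c(F)cccc4F)(C(F)(F)F)C(F)(F)F)cc3)(S(=O)(=O)c3ccc(F)cc3)C2)C1` gives 9%
Compound 2 `CC(=O)N1CCC(O)(C(=O)N2CC[C@](c3ccc(C(OCc4c(F)cccc4F)(C(F)(F)F)C(F)(F)F)cc3)(S(=O)(=O)c3ccc(F)cc3)C2)CC1` gives 16%
Compound 3 `O=C(C1CCOCC1)N1CC[C@](c2ccc(C(OCc3c(F)cccc3F)(C(F)(F)F)C(F)(F)F)cc2)(S(=O)(=O)c2ccc(F)cc2)C1` gives 11%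

Compound 3, at 11%, lies within the scatter of both other compounds: a number 2 percentage points higher from compound 1 to compound 3 (within the scatter) and a number 5 percentage points lower from compound 2 to compound 3 (within the scatter). Compound 4 `O=C(O)C1CCN(C(=O)N2CC[C@](c3ccc(C(OCc4c(F)cccc4F)(C(F)(F)F)C(F)(F)F)cc3)(S(=O)(=O)c3ccc(F)cc3)C2)CC1` has not been measured. It carries 4-carboxypiperidin-1-yl in place of oxan-4-yl on a carbonyl carbon. The two steps above bear on this change, as does a number 7 percentage points higher from compound 1 to compound 2 (within the scatter), since all three exchange groups at that carbonyl carbon. None brings in the 4-carboxypiperidin-1-yl group, so they bound this change only loosely. In this assay a modest upward step is expected, near the edge of the scatter. The expected step is a number 11 percentage points higher from compound 3 to compound 4 (beyond the scatter). For compound 4 the estimated value is 22%, with an expected range from 8% to 60%.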

Compound 4, percent of the compound remaining: 72%
Compound 4: middle estimate off by 50 percentage points, on the low side, outside the stated range (above it).
By their numbers in this assay, from the lowest: compounds 1, 3 and 2 (each within the scatter of the next); then compound 4.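

In this assay the earlier groups on this carbonyl carbon all stayed within the scatter of one another, so the position had seemed to make little difference. The change to 4-carboxypiperidin-1-yl now shows that it can shift the read-out strongly, with a number 61 percentage points higher from compound 3 to compound 4 (beyond the scatter) and a number 56 percentage points higher from compound 2 to compound 4 (beyond the scatter) and also a number 63 percentage points higher from compound 1 to compound 4 (beyond the scatter) on the same scale. Nothing measured here accounts for this rise. The compounds shown leave open whether the carboxylic acid or the ring nitrogen on the carbonyl carbon carries the step. A methyl ester, a primary amide or a piperidine without the carboxylic acid would separate the two.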